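Swapping an aryl-substituted amine for a dialkyl amine

The source may report more compounds than this note shows. Statements on the series, on what has been measured and on what is new or still open speak of the compounds shown alone.

Of the compounds shown here, three sharing one core have been measured in an assay on HEK293 cells for inhibition of Steryl-sulfatase (Homo sapiens), tested at 0.1 uM; a lower number here means a weaker effect, a higher number a stronger effect of the compound at the concentration tested. Compound 1 `CCN(Cc1ccccc1)Cc1ccc(CN2CCc3ccc(OS(N)(=O)=O)cc3C2)cc1` gives 1%. Compound 3 `CCN(Cc1ccncc1)c1ccc(C(=O)N2CCc3ccc(OS(N)(=O)=O)cc3C2)cc1` gives 47%. Compound 2 `CCN(Cc1ccc(Br)cc1)c1cccc(C(=O)N2CCc3ccc(OS(N)(=O)=O)cc3C2)c1` gives 24.2%, which places compound 2 second highest of the three; compound 3 lies closer to it but beyond the scatter, while compound 1 lies furthest, also beyond the scatter.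

The step of interest leads from compound 2 to compound 4 `CC(C)CCN(CCC(C)C)c1cccc(C(=O)N2CCc3ccc(OS(N)(=O)=O)cc3C2)c1`, which has not yet been measured. The change is diisopentylamino in place of (4-bromobenzyl)(ethyl)amino on an aromatic carbon, on an aromatic carbon of a six-membered aromatic ring of carbon only, meta to a large group. For the measured compounds named here, no step between two measured compounds covers this kind of change, so there is nothing in the numbers to lean on. The account therefore treats the step as expected to be small, possibly downward, and within or near the scatter, which the estimated step of a number 4.2 percentage points lower from compound 2 to compound 4 (within the scatter) expresses. Compound 4 is estimated to give 20%, in a range from 5% to 45%.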

Compound 4, a percentage reported as inhibition, at one concentration (the size of the read-out at that concentration, not a potency): 32.3%
Estimate against measurement, compound 4: 12.3 percentage points below; the range from low to high includes it.
By their numbers in this assay, from the lowest: compound 1; then compounds 2 and 4 (each within the scatter of the next); then compound 3.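

In this assay, for the compounds shown here, replacing (4-bromobenzyl)(ethyl)amino with diisopentylamino on this aromatic carbon, meta to a large group, gives a number 8.1 percentage points higher from compound 2 to compound 4 (within the scatter) and provides the first direct comparison at this position. Within this single pair, the six-membered aromatic ring and the bromine of the departing group can be lost without a change beyond the scatter, with two branched chains taking their place at the same heavy-atom count. The pair cannot show whether the same holds on any other scaffold or at any other position. No available measurement accounts for this result.

The compounds shown leave open how a shorter diethylamino group or a ring amine such as piperidine would read at this place. They also leave open how a benzyl group without the bromine would compare with the (4-bromobenzyl)(ethyl)amino group.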